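This account rests on a few compounds, and the source may have more. Where it says the series, first, only, none or still open, it means among the compounds named here.

The measured compounds, each with its number in a functional assay on HT cells (Homo sapiens) for antiproliferative activity, read by fluorescence, with a stated time of 72 h; on this read-out lower numbers stand for stronger inhibition of growth and higher numbers for weaker inhibition of growth:
compound 1, `CC(C)c1n[nH]c2c(NCc3ccc(-c4ccccn4)cc3)nc(SCC(N)=O)nc12`, gives 192 nM;
compound 2, `CNCCSc1nc(NCc2ccc(-c3ccccn3)cc2)c2[nH]nc(C(C)C)c2n1`, gives 56 nM;
compound 3, `CC(C)c1n[nH]c2c(NCc3ccc(-c4ccccn4)cc3)nc(SCCCO)nc12`, gives 109 nM.

Among these three, compound 3 holds the second highest number, but it is not set apart from either neighbour: the step of a 1.8-fold lower number from compound 1 to compound 3 (0.25 log units; within the scatter) and the step of a 1.9-fold higher number from compound 2 to compound 3 (0.29 log units; within the scatter) both lie within the scatter.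

Compound 4, `CC(C)c1n[nH]c2c(NCc3ccc(-c4ccccn4)cc3)nc(SCC(C)(C)N)nc12`, is reached from compound 3 by one change: 1-amino-1-methylethyl in place of 2-hydroxyethyl on a saturated chain carbon bound to a sulfur

For the measured compounds named here, two measured steps bear on this. Going by the values given here, replacing carbamoyl with (methylamino)methyl on the chain bound to sulfur gave a 3.4-fold lower number from compound 1 to compound 2 (0.54 log units; beyond the scatter), the only step here beyond the scatter. Replacing methylamino with hydroxymethyl further along the chain gave a 1.9-fold higher number from compound 2 to compound 3 (0.29 log units; within the scatter). The present change again exchanges a hydroxyl-bearing chain for an amine-bearing one, the same sense as the first of these steps and the reverse of the second, so a modestly lower number is expected, at the edge of the scatter: a 1.8-fold lower number from compound 3 to compound 4 (0.26 log units; within the scatter). Compound 4 is therefore estimated at 60 nM in this assay, with a likely range from 25 nM to 150 nM.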

Compound 4, concentration for 50% growth inhibition: 85 nM
Estimate against measurement, compound 4: 1.4-fold (0.15 log units) below; the range from low to high includes it.
By their numbers in this assay, from the lowest: compounds 2, 4, 3 and 1 (each within the scatter of the next, the first and the last beyond it).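

In this assay, 1-amino-1-methylethyl in place of 2-hydroxyethyl on a saturated chain carbon bound to a sulfur gives a 1.3-fold lower number from compound 3 to compound 4 (0.11 log units; within the scatter) and so does not separate the amine-bearing chain from the hydroxyl-bearing one, while the comparison with the other amine-bearing chain, a 1.5-fold higher number from compound 2 to compound 4 (0.18 log units; within the scatter), does not separate 1-amino-1-methylethyl from (methylamino)methyl either. Against carbamoyl the new chain gives a 2.3-fold lower number from compound 1 to compound 4 (0.35 log units; beyond the scatter), a modest step that makes compound 4 the second compound, after compound 2, to stand apart from compound 1. Compound 3 goes against any clean division by amine. It remains within the scatter of compound 1 and of both amine-bearing compounds. Nothing measured here explains why these chains compare as they do.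

The compounds shown leave open whether the two methyl groups of 1-amino-1-methylethyl matter, which an unbranched aminomethyl chain of the same kind would help to test. They also leave open whether a dimethylamino group, a carboxylic acid or a longer chain at this place would give a number that stands apart from those of compound 2 and compound 4.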